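Trimming one methyl from the aryl ketone of compound 3

This account rests on a few compounds, and the source may have more. Where it says the series, first, only, none or still open, it means among the compounds named here.

Within the data shown here, compound 3 `COc1ccc(/C=C/c2cc(OC)cc(OC)c2/C=C/C(=O)c2ccc(C)c(C)c2)cc1` gives the lowest number of the three measured so far in a functional assay on HepG2 cells (Homo sapiens) for antiproliferative activity, read by MTT assay, with a stated time of 48 h (on this read-out lower numbers stand for stronger inhibition and higher numbers for weaker inhibition), at 0.2 ug/mL. Compound 1 `COc1ccc(/C=C/c2cc(OC)cc(OC)c2/C=C/C(=O)c2ccccc2)cc1` gives 6.8 ug/mL in this assay, and compound 2 `COc1ccc(/C=C/c2cc(OC)cc(OC)c2/C=C/C(=O)c2cccc(Br)c2)cc1` gives 13 ug/mL. Both steps into compound 3 are large: a 34-fold lower number from compound 1 to compound 3 (1.53 log units; beyond the scatter) and a 65-fold lower number from compound 2 to compound 3 (1.81 log units; beyond the scatter). By contrast a 1.9-fold higher number from compound 1 to compound 2 (0.28 log units; within the scatter) stays within the scatter.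

Compound 4 `COc1ccc(/C=C/c2cc(OC)cc(OC)c2/C=C/C(=O)c2ccc(C)cc2)cc1` differs from compound 3 in one place: hydrogen in place of methyl on an aromatic carbon. The methyl that leaves sits ortho to a methyl group and meta to a large group, so that 3,4-dimethylphenyl becomes 4-methylphenyl on the carbonyl carbon.

Among the measured compounds shown here, the step that bears on this is the one from compound 1 to compound 3, in which both methyls arrive together and the number falls far beyond the scatter. For the measured compounds named here, no measured step separates the contribution of the two methyls, so the share of the one that leaves here is unknown. Removing one of the two is expected to give back part of that drop, with compound 4 expected to land between compound 3 and compound 1 rather than at either end; the expected step is a 5.0-fold higher number from compound 3 to compound 4 (0.70 log units; beyond the scatter), a higher number, probably beyond the scatter. For compound 4 the estimate in this assay is 1 ug/mL, with a range from 0.3 ug/mL to 4 ug/mL.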

Compound 4, half-maximal inhibitory concentration: 4.8 ug/mL
For compound 4 the middle estimate is 4.8-fold (0.68 log units) below the measured one; the whole stated range lies below it.
By their numbers in this assay, from the lowest: compound 3; then compounds 4, 1 and 2 (each within the scatter of the next, the first and the last beyond it).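

In this assay the methyl that leaves here carries far more weight than its single carbon suggests: a 24-fold higher number from compound 3 to compound 4 (1.38 log units; beyond the scatter) is large, and it takes away almost all of the advantage that the 3,4-dimethylphenyl ketone holds over the others. The methyl that stays does not hold that advantage on its own, since a 1.4-fold lower number from compound 1 to compound 4 (0.15 log units; within the scatter) leaves 4-methylphenyl not separated from phenyl, while a 2.7-fold lower number from compound 2 to compound 4 (0.43 log units; beyond the scatter) is only a modest step, so among these four compounds the low number appears only when both methyls are present. The shown data contain no measurement that accounts for this dependence on the second methyl.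

The compounds shown leave open whether the methyl at this place needs the methyl at the other place at all, since none carries it without that partner. Also open, as far as these compounds go, is whether ethyl, methoxy, chloro or an amine, set ortho to a methyl group in place of the methyl lost here, would keep the low number of compound 3.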